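Swapping the aryl on the ring nitrogen of compound 3

This account rests on a few compounds, and the source may have more. Where it says the series, first, only, none or still open, it means among the compounds named here.

Of the compounds shown here, three have been measured in a functional assay on HEK293 cells with D(4) dopamine receptor (Homo sapiens) as the target, read by FLIPR; on this read-out lower numbers stand for an effect already at smaller amounts and higher numbers for an effect only at larger amounts of compound. Compound 1 `Cc1cccc(/C(CCN2CCN(c3ccccn3)CC2)=N/O)c1` gives 2.3 nM. For the measured compounds named here, compound 2 `O/N=C(\CCN1CCN(c2ccccn2)CC1)c1ccc(Cl)cc1` gives 475 nM, and the step of a 210-fold higher number from compound 1 to compound 2 (2.31 log units; beyond the scatter) is the only single-point change measured so far. Compound 3 `CCO/N=C(\CCN1CCN(c2ccccc2C#N)CC1)c1ccccc1` gives 48.7 nM, the second highest of the three numbers, sitting nearer to compound 2 than to compound 1.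

Compound 4 `CCO/N=C(\CCN1CCN(c2cccc(OC)c2)CC1)c1ccccc1` has not yet been measured. It differs from compound 3 in one place: 3-methoxyphenyl in place of 2-cyanophenyl on an amine nitrogen in a ring. Going by the values given here, no measured step touches the group on that ring nitrogen; the one step known concerns the aryl on the carbon with the double bond to nitrogen, so it gives no direct guide here. With no bearing evidence, the expected outcome is a step of no clear direction, and most likely none beyond the scatter.

The step from compound 3 to compound 4 is estimated as a 1.2-fold higher number from compound 3 to compound 4 (0.09 log units; within the scatter). Compound 4 is therefore expected to give about 60 nM in this assay, within a range from 12 nM to 300 nM.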

Compound 4, half-maximal effective concentration: 2680 nM
Compound 4: the middle estimate sits 45-fold (1.65 log units) below what was measured; the measured number lies above the stated range.
By their numbers in this assay, from the lowest: compound 1; then compound 3; then compound 2; then compound 4.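

In this assay, the aryl on the amine nitrogen in the ring proves to be a sensitive position: 3-methoxyphenyl in place of 2-cyanophenyl gives a 55-fold higher number from compound 3 to compound 4 (1.74 log units; beyond the scatter) with the rest of the molecule unchanged. For the compounds shown here, until now, the only single-point change concerned the aryl on the carbon with the double bond to nitrogen, so this is the first sign that the other end of the molecule also matters. The two groups have the same heavy-atom and hydrogen-bond acceptor counts, so these counts do not account for the gap, and no measurement at hand explains it.

Still open, as far as these compounds go, is whether the rise follows the nitrile and methoxy groups themselves or the place each holds on the phenyl ring. A plain phenyl group on that nitrogen would give a reference point for both.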